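The source may report more compounds than this note shows. Statements on the series, on what has been measured and on what is new or still open speak of the compounds shown alone.

In a functional assay on MES-SA cells (Homo sapiens) for inhibition, with a stated time of 72 h, in the presence of a further agent that is not named here (a lower number here means a stronger inhibitor, a higher number a weaker inhibitor), compound 1 `COCc1cc(CN2CCCCC2)c(O)c2ncccc12` gives 9550 nM, the higher of the two numbers available, and a further entry for it gives no single number. Compound 2 `CC1CCN(Cc2cc(Cl)c3cccnc3c2O)CC1` gives 2880 nM; 2880 nM (2 entries), but it differs from compound 1 in more than one place. Compound 3 `COCc1cc(CN2CCC(C)CC2)c(O)c2ncccc12` keeps the core of compound 1 and replaces piperidin-1-yl with 4-methylpiperidin-1-yl, methyl in place of hydrogen on a saturated ring carbon. For the measured compounds named here, no measured pair isolates this change, so only a modest gain is expected, with the estimated step of a 1.7-fold lower number from compound 1 to compound 3 (0.24 log units; within the scatter) possibly staying within the scatter. Compound 3 is estimated at 5500 nM, with an expected range of 2200 nM to 13000 nM.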

Compound 3, half-maximal inhibitory concentration: 6460 nM
Compound 3: middle estimate off by 1.2-fold (0.07 log units), on the low side; the measured number falls inside the stated range.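

In this assay, for the compounds shown here, the first pair to isolate methyl in place of hydrogen on a saturated ring carbon shows a 1.5-fold lower number from compound 1 to compound 3 (0.17 log units; within the scatter) and so does not separate piperidin-1-yl from 4-methylpiperidin-1-yl. At this place, three ring bonds from the ring nitrogen, a single methyl therefore leaves the number within the scatter. Nothing at hand bears on the reason for this result. Still open, on these data alone, is whether a hydroxyl, a primary amine or a phenyl on this ring carbon would give a step beyond the scatter. This one pair also leaves open whether the methyl behaves alike on another core.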